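Swapping a Chloro for a Carboxy on a Receptor Agonist

The source may hold more compounds than are shown below. What is called first, only, known or untested is meant among the compounds shown, and "the series" means these compounds.

The measured compounds so far:
Compound 1 `O=C(O)CCc1ccc(NCc2ccc(Cl)cc2)cc1` gives 1000 nM.
Compound 2 `O=C(O)CCc1ccc(NCc2ccc(Cl)c(Cl)c2)cc1` gives 251 nM.
Compound 3 `O=C(O)CCc1ccc(NCc2ccccc2Cl)cc1` gives 3980 nM.

All three share one core, carrying a pendant aromatic ring that differs only in where and how many chloro groups it bears. In a functional assay for agonist activity at Free fatty acid receptor 1 (Homo sapiens) (on this read-out higher numbers stand for an effect only at larger amounts of compound and lower numbers for an effect already at smaller amounts), compound 1 stands second highest of the three numbers. Its nearest neighbour is compound 3, whose number is higher; compound 2 sits furthest away with the lowest number.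

The new compound, compound 4 `O=C(O)CCc1ccc(NCc2ccc(C(=O)O)cc2)cc1`, is reached from compound 1 by one change: carboxy in place of chloro on an aromatic carbon. Going by the values given here, no measured step removes a chloro or introduces a carboxy, so none bears directly on this change. Among the compounds with values here, the only step, a 4.0-fold lower number from compound 1 to compound 2 (0.60 log units; beyond the scatter), shows that a second chloro brings a modest gain, and compound 3 shows a chloro elsewhere on the ring giving a higher number. Taking the chloro away altogether and putting a carboxy in its place is therefore expected to move the number up, beyond the scatter, in this assay.

On that basis compound 4 is estimated at 5000 nM, within 1500 nM to 20000 nM, which means an expected step of a 5.0-fold higher number from compound 1 to compound 4 (0.70 log units; beyond the scatter).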

Compound 4, half-maximal effective concentration: < 31700 nM
Compound 4 gave a limit, no number (the forecaster's own chance of this, stated with the estimate: 25%); the middle value lies beyond the limit too.
By their numbers in this assay, from the lowest: compound 2; then compound 1; then compound 3.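

In this assay compound 4 gives < 31700 nM, which is a limit and not a number. The step from compound 1 to compound 4 therefore cannot be read, because all that stands for compound 4 is: the limit of < 31700 nM in this assay, at which 1 of the 4 values shown sits.

The compounds shown leave open how far, and in which direction, carboxy in place of chloro on an aromatic carbon moves the number in this assay.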